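Swapping a trifluoromethyl for chloro on the urea aryl ring

This account rests on a few compounds, and the source may have more. Where it says the series, first, only, none or still open, it means among the compounds named here.

Of the compounds shown here, two have been tested so far in a functional assay on LOX IMVI cells (Homo sapiens) for inhibition, read by sulforhodamine B assay, with a stated time of 48 h, tested at 1 uM; a lower number here means a stronger effect, a higher number a weaker effect of the compound at the concentration tested. Compound 1 `O=C(Nc1cccc(-n2cc(-c3ccncc3)c(-c3cc(O)cc(Cl)c3)n2)c1)Nc1ccc(Cl)c(Cl)c1` gives 83% in this assay. Compound 2 `COc1cc(Cl)cc(-c2nn(-c3cccc(NC(=O)Nc4ccc(Cl)c(C(F)(F)F)c4)c3)cc2-c2ccncc2)c1` gives 61%, the lower of the two numbers; the gap to compound 1 lies beyond the usual scatter. Among the compounds with values here, no pair of measured compounds differs in only one place, so no single step in this assay has yet been measured.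

Compound 3 `COc1cc(Cl)cc(-c2nn(-c3cccc(NC(=O)Nc4ccc(Cl)c(Cl)c4)c3)cc2-c2ccncc2)c1` is the next compound. It differs from compound 2 in one place: chloro in place of trifluoromethyl on an aromatic carbon. Within the data shown here, with only two measured numbers and no comparable step available, the size of the step from compound 2 to compound 3 in this assay cannot be read off from the data; a modest rise is expected, a number 9 percentage points higher from compound 2 to compound 3 (within the scatter), but a change within the scatter would not be surprising. Compound 3 is therefore expected to give about 70% in this assay, in a range from 50% to 90%.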

Compound 3, a percentage reported as activity, at one concentration (the size of the read-out at that concentration, not a potency): 91%
Compound 3: middle estimate off by 21 percentage points, on the low side, and the stated range ends below it.
By their numbers in this assay, from the lowest: compound 2; then compounds 1 and 3 (each within the scatter of the next).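

On this aromatic carbon, ortho to a chloro group, the choice of substituent matters: replacing trifluoromethyl with chloro gives a number 30 percentage points higher from compound 2 to compound 3 (beyond the scatter) in this assay, which means a weaker effect at the concentration tested. The other new comparison, methyl in place of hydrogen on an oxygen on an aromatic ring, gives a number 8 percentage points higher from compound 1 to compound 3 (within the scatter), so with the 3,4-dichlorophenyl group in place this change does not separate the two compounds. Nothing available accounts for the difference between trifluoromethyl and chloro at this position.

Still open, going by these compounds, is how a bromo, a methyl or a nitrile on this same aromatic carbon would read in this assay. Also open, on these data alone, is whether the trifluoromethyl-to-chloro step would hold its size if that oxygen carried hydrogen instead of methyl.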